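This account rests on a few compounds, and the source may have more. Where it says the series, first, only, none or still open, it means among the compounds named here.

In a functional assay on HEK293 cells (Homo sapiens) for cytotoxicity (on this read-out lower numbers stand for higher toxicity in this test and higher numbers for lower toxicity in this test), compound 1 (`COc1ccc([C@H]2CC(=O)N(c3cccc(NS(=O)(=O)c4cccc(OC(F)(F)F)c4)c3)C2)cc1OC1CCCC1`) is reported only as a limit, > 10000 nM. Compound 2 (`COc1ccc([C@H]2CC(=O)N(c3cccc(NS(=O)(=O)c4cccc(Cl)c4C)c3)C2)cc1OC1CCCC1`) is also reported only as a limit, > 10000 nM. Compound 2 therefore has no numerical value and stands at the limit of > 10000 nM in this assay, at which 2 of the 2 values shown sit. Compound 3 (`COc1ccc([C@H]2CC(=O)N(c3cccc(NS(=O)(=O)c4ccccc4Cl)c3)C2)cc1OC1CCCC1`) carries 2-chlorophenyl in place of 3-chloro-2-methylphenyl on a sulfonyl sulfur. Going by the values given here, the one measured step that bears on this change is a step that the two limits leave unreadable from compound 1 to compound 2, which exchanged the group at that same place. Among the compounds with values here, it gives no size to carry over, and it rests on only two compounds. Still, neither compound 1 nor compound 2 left the limit across a step that the two limits leave unreadable from compound 1 to compound 2, so no clear shift toward higher toxicity is expected for compound 3. What is expected is a step that the limit leaves unreadable from compound 2 to compound 3, and the assay will most likely report a limit again. For compound 3 the estimated value is 12000 nM, with an expected range of 6000 nM to 30000 nM.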

Compound 3, half-maximal cytotoxic concentration: > 10000 nM
Compound 3 was reported as a limit; the forecaster's own chance of this, stated with the estimate: 85%; the middle value lies beyond the limit too.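

In this assay, going by these compounds alone, compound 3 is reported only as a limit, > 10000 nM, so no step among compound 1, compound 2 and compound 3 can be read. The compounds shown leave open how far beyond the limit each of the three lies, and whether any group on the sulfonyl sulfur would give a readable value in this assay.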